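Extending the alkynyl chain of a nucleoside analogue

The compounds below may be only part of what the source reports. "The series", "measured", "known", "first", "only" and "open" are said of these compounds alone.

Compound 3 `CCCCCCC#Cc1cc2cn([C@@H]3O[C@H](CO)[C@@H](O)[C@H]3O)c(=O)nc2o1` was examined in a functional assay on HEL cells (Homo sapiens) for cytotoxicity; a lower number here means that less compound is tolerated, a higher number that more compound is tolerated. In this assay compound 3 gives only a limit, > 133000 nM. Compound 1 `CCCCC#Cc1cc2cn([C@@H]3O[C@H](CO)[C@@H](O)[C@H]3O)c(=O)nc2o1` likewise reaches only a limit in this assay, > 144000 nM. Compound 2 `CCCCCCCCCCC#Cc1cc2cn([C@@H]3O[C@H](CO)[C@@H](O)[C@@H]3O)c(=O)nc2o1`, which carries a different configuration on the sugar, gives 116000 nM in this assay. Compound 3 thus stands at the top of the measured range, where one further value is also a limit. Going by the values given here, the single one-place step in hand, a step that the two limits leave unreadable from compound 1 to compound 3, cannot be read for size or direction, since the limit of > 133000 nM in this assay, at which 1 of the 3 values shown sits, and the limit of > 144000 nM in this assay, at which 1 of the 3 values shown sits, both sit at limits.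

Compound 4 `CCCCCCCCCCC#Cc1cc2cn([C@@H]3O[C@H](CO)[C@@H](O)[C@H]3O)c(=O)nc2o1` differs from compound 3 by butyl in place of hydrogen on a saturated chain carbon, six bonds along the chain from a triple-bonded carbon. Among the compounds with values here, no readable step bears on this change; the only measured step, from compound 1 to compound 3, is unreadable, so it offers neither size nor direction. Compound 2 carries the same chain as compound 4 and gives a number close to the limits of the other two compounds. Compound 4 is therefore expected to give about 120000 nM, with a range from 60000 nM to 250000 nM. The estimated step of an at least 1.1-fold lower number from compound 3 to compound 4 (0.04 log units; that floor lies within the scatter) is expected to be small, with a real chance that only a limit is again reported.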

Compound 4, half-maximal cytotoxic concentration: 44000 nM
Compound 4: middle estimate off by 2.7-fold (0.44 log units), on the high side; measured number below the stated range.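

Butyl in place of hydrogen on a saturated chain carbon, six bonds along the chain from a triple-bonded carbon, gives the first readable chain step in this series: this assay shows an at least 3.0-fold lower number from compound 3 to compound 4 (0.48 log units; beyond the scatter), so less compound is tolerated once the chain carries the added butyl. A larger addition to the chain points the same way, with an at least 3.2-fold lower number from compound 1 to compound 4 (0.51 log units; beyond the scatter). The chain is not the only place that counts in this assay, since a stereocentre at a saturated ring carbon, drawn S in compound 2 and R in compound 4, goes with a 2.6-fold lower number from compound 2 to compound 4 (0.42 log units; beyond the scatter), and that step can be set on configuration alone: the fact that compounds 2 and 4 differ only in the configuration as drawn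

As far as these compounds go, the step from compound 1 to compound 3 still cannot be read, as both compounds give only limits, so it stays open whether the number starts to fall at the shorter chains or only at the chain of compound 4. Also open, from the compounds shown here alone, is whether a longer chain than that of compound 4, or a hydroxyl or an amine at the chain end, would move the number in this assay.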